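Cytotoxicity notes: pyridine N-oxide to pyridine swap

A few compounds are considered here, and "the series" means these few. Any claim that something is new, unique, unknown or untested is made for them only; others in the source may bear on it.

Two compounds of this series have a reading in an ADME assay on MT2 cells (Homo sapiens) for cytotoxicity, read by MTT assay; on this read-out higher numbers stand for lower toxicity in this test and lower numbers for higher toxicity in this test. Compound 1 `[O-][n+]1ccc(OCc2ccc(Nc3ncc(Cc4c(F)cccc4F)o3)cc2Cl)cc1` gives 1700 nM and is the lowest of the two numbers; compound 2 `Fc1cccc(F)c1Cc1cnc(Nc2ccc(Oc3cccnc3)c(Br)c2)o1` gives 7500 nM, the higher of the two and beyond the scatter from compound 1. Compound 3 `Fc1cccc(F)c1Cc1cnc(Nc2ccc(COc3ccncc3)c(Cl)c2)o1` is unmeasured in this assay. It differs from compound 1 by a group of 6 heavy atoms (5 carbon, 1 nitrogen; one six-membered aromatic ring with 1 hetero atom) in place of a group of 7 heavy atoms (5 carbon, 1 nitrogen, 1 oxygen; one six-membered aromatic ring with 1 hetero atom), on an oxygen on a saturated carbon. Going by the values given here, no comparable step has been measured, so the direction is uncertain; a small upward shift, a 1.6-fold higher number from compound 1 to compound 3 (0.22 log units; within the scatter), is expected, not beyond the usual scatter with confidence. Compound 3 is therefore estimated at 2800 nM, with a range from 1000 nM to 8000 nM.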

Compound 3, half-maximal cytotoxic concentration: 3800 nM
Estimate against measurement, compound 3: 1.4-fold (0.13 log units) below; low and high end bracket the measured number.
By their numbers in this assay, from the lowest: compound 1; then compounds 3 and 2 (each within the scatter of the next).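

Going by these compounds alone, this is the first single-place step: on an oxygen on a saturated carbon, pyridin-4-yl in place of the pyridine N-oxide group gives in this assay a 2.2-fold higher number from compound 1 to compound 3 (0.35 log units; beyond the scatter) and is modest. The oxygen on the ring nitrogen therefore makes a small difference at this position, with its absence going with lower toxicity in this test. Nothing available explains this shift.

As far as these compounds go, whether a phenyl ring or an amine on that same oxygen would read like pyridin-4-yl remains open. So does whether the same swap gives a step of this size on another core.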